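A few compounds are considered here, and "the series" means these few. Any claim that something is new, unique, unknown or untested is made for them only; others in the source may bear on it.

Measured so far:
compound 1, `COc1ccccc1NC(=O)NC1CC(C)(C)Oc2ccc(Cl)cc21`, a functional assay (aorta) with Rattus norvegicus as the target; on this read-out higher numbers stand for an effect only at larger amounts of compound and lower numbers for an effect already at smaller amounts: > 10000 nM
compound 2, `Cc1ccc(NC(=O)NC2CC(C)(C)Oc3ccc(F)cc32)cc1`, this assay: > 30000 nM

In this assay compound 1 reached only a limit of the limit of > 10000 nM in this assay, at which 1 of the 2 values shown sits, rather than a number. Compound 2 likewise gave only a limit, (the limit of > 30000 nM in this assay, at which 1 of the 2 values shown sits), and no number. Compound 2 therefore stands nowhere that can be placed on a scale: both values shown are limits, and nothing orders the two compounds.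

Compound 3, `Cc1ccc(NC(=O)NC2CC(C)(C)Oc3ccc(Cl)cc32)cc1`, differs from compound 2 in one place: chloro in place of fluoro on an aromatic carbon. Compound 1 carries the same chloro and still reached only its limit, so the step from compound 2 to compound 3 in this assay is expected to be none beyond the scatter, a number no higher from compound 2 to compound 3 (the limit leaves the size open). For compound 3 the expected value in this assay is 30000 nM, within 10000 nM to 100000 nM, most likely reported again as a limit.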

Compound 3, half-maximal effective concentration: > 30000 nM
Compound 3: only a limit was reported; the forecaster's own chance of this, stated with the estimate: 85%; the middle value lies on the limit itself.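

In this assay compound 3 gave only a limit, > 30000 nM. Compound 1 and compound 2 also gave only limits, and the steps from each of them to compound 3 cannot be read. The compounds shown leave open whether chloro and fluoro differ at all in this assay.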